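The source may hold more compounds than are shown below. What is called first, only, known or untested is meant among the compounds shown, and "the series" means these compounds.

Compound 1 `Nc1ccccc1NC(=O)/C=C/c1ccc(CSc2ccc(Cl)cc2)cc1`: 16.5%
Compound 2 `Nc1ccccc1NC(=O)c1ccc(CSc2ccc(C(F)(F)F)cn2)cc1`: 7.57%

Both numbers come from a functional assay on SMMC-7721 cells (Homo sapiens) for inhibition, read by CCK-8 assay, with a stated time of 72 h, tested at 8 uM; a higher number here means more inhibition of growth at the concentration tested, a lower number less inhibition of growth. Compound 1 carries the higher of the two figures, but its distance to compound 2 lies within the scatter, so the two cannot be ranked against each other.

Compound 3 `Nc1ccccc1NC(=O)/C=C/c1ccc(CSCCc2ccccc2)cc1` has not yet been measured. Relative to compound 1 the change is phenethyl in place of 4-chlorophenyl on a sulfur. Among the measured compounds shown here, no step between two measured compounds resembles this exchange, so there is no guide to its size; the step from compound 1 to compound 3 is expected to be small, a number 3.5 percentage points lower from compound 1 to compound 3 (within the scatter), and not beyond the scatter. Compound 3 is therefore estimated at 13%, within a range from 3% to 25%.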

Compound 3, percent growth inhibition at one concentration: 15.8%
Compound 3: the middle estimate sits 2.8 percentage points below what was measured, and the stated range covers the measured number.
By their numbers in this assay, from the lowest: compounds 2, 3 and 1 (each within the scatter of the next).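

In this assay, putting phenethyl in place of 4-chlorophenyl on the sulfur gives a number 0.7 percentage points lower from compound 1 to compound 3 (within the scatter). On this sulfur, then, an aromatic ring carrying chlorine and phenethyl, which has no chlorine, cannot be told apart, so this exchange shows no readable effect at the concentration tested. No measurement on hand bears on why the two compounds match.

Still open, going by these compounds, is whether a group of another kind on this sulfur, such as an amine or a carboxylic acid, would shift growth inhibition beyond the scatter. A longer chain ending in the same phenyl ring is equally untested here.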